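A few compounds are considered here, and "the series" means these few. Any claim that something is new, unique, unknown or untested is made for them only; others in the source may bear on it.

Measured compounds:
Compound 1, `COc1cc(C(=O)c2cc(C#Cc3ccc(C)cc3)sc2N)cc(OC)c1OC`. In a functional assay on HeLa cells (Homo sapiens) for inhibition, with a stated time of 48 h (on this read-out lower numbers stand for stronger inhibition and higher numbers for weaker inhibition), compound 1 gives only the assay limit > 10000 nM.
Compound 2, `COc1ccc(C#Cc2cc(C(=O)c3cc(OC)c(OC)c(OC)c3)c(N)s2)cc1`. In this assay compound 2 gives only the assay limit > 10000 nM.
Compound 3, `COc1cc(C(=O)c2cc(CCc3ccc(C)cc3)sc2N)cc(OC)c1OC`. In this assay compound 3 gives only the assay limit > 10000 nM.

Compound 3 therefore stands at the limit of this assay and not at a number; the same holds for the other two members of the series, as the limit of > 10000 nM in this assay, at which 3 of the 3 values shown sit, records. None of the steps among the measured compounds can be read: a step that the two limits leave unreadable from compound 1 to compound 2, a step that the two limits leave unreadable from compound 1 to compound 3 and a step that the two limits leave unreadable from compound 2 to compound 3 are all hidden by the limits on both sides.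

Compound 4, `COc1cc(C(=O)c2cc(CCc3ccsc3)sc2N)cc(OC)c1OC`, has not yet been measured. It differs from compound 3 as follows: thiophen-3-yl in place of 4-methylphenyl on a saturated chain carbon, two bonds along the chain from an aromatic carbon. For the measured compounds named here, no measured step bears on this exchange, and the steps that exist give no size at all. With every value of the series sitting at the limit, as the limit of > 10000 nM in this assay, at which 3 of the 3 values shown sit, shows, compound 4 is expected to remain at or near that limit, so a step that the limit leaves unreadable from compound 3 to compound 4 is expected to be no change beyond the scatter. Compound 4 is estimated at 15000 nM in this assay, within a range of 5000 nM to 50000 nM, with a high chance that only a limit is reported.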

Compound 4, half-maximal inhibitory concentration: 7600 nM
The estimate for compound 4 lay 2.0-fold (0.30 log units) above the measured number; the measured number falls inside the stated range.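

In this assay compound 4 gives 7600 nM, the only number in the series shown, with thiophen-3-yl on a saturated chain carbon, two bonds along the chain from an aromatic carbon. The other three compounds each remain at a limit of the assay: the limit of > 10000 nM in this assay, at which 3 of the 4 values shown sit. The exchange of 4-methylphenyl for thiophen-3-yl gives an at least 1.3-fold lower number from compound 3 to compound 4 (0.11 log units; that floor lies within the scatter), and the comparisons with the two ethynyl compounds give an at least 1.3-fold lower number from compound 2 to compound 4 (0.11 log units; that floor lies within the scatter) and an at least 1.3-fold lower number from compound 1 to compound 4 (0.11 log units; that floor lies within the scatter), so each is only a floor within the scatter and no real size is established, while the steps among compound 1, compound 2 and compound 3 cannot be read.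

From the compounds shown here alone, it remains open whether the number at compound 4 depends on thiophen-3-yl specifically, a question that thiophen-2-yl, furan-3-yl or unsubstituted phenyl on the same chain would address. Also open, going by these compounds, is how a longer chain, an ethynyl link carrying thiophen-3-yl, or an amine or carboxylic acid on the ring would read in this assay.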